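The source may hold more compounds than are shown below. What is called first, only, known or untested is meant among the compounds shown, and "the series" means these compounds.

Working notes on the series. Compound 1 `CN(C)CCn1cnnc1-c1cc(Oc2ccc(NC(=O)N/N=C/c3ccc(F)cc3)cc2F)ccn1` gives 1980 nM in a functional assay on NCI-H460 cells (Homo sapiens) for cytotoxicity, read by MTT assay, with a stated time of 72 h; a higher number here means a weaker inhibitor, a lower number a stronger inhibitor. Compound 2 `CN(C)CCn1cnnc1-c1cc(Oc2ccc(NC(=O)N/N=C/c3ccc(F)cc3F)cc2F)ccn1` gives 1930 nM in this assay, and compound 3 `CN(C)CCn1cnnc1-c1cc(Oc2ccc(NC(=O)N/N=C/c3ccc(O)c(O)c3)cc2F)ccn1` gives 1930 nM there. Compound 2 stands level with compound 3 at the digits shown, the two together the lowest of three numbers, while compound 1 differs from it by a 1.0-fold lower number from compound 1 to compound 2 (0.01 log units; within the scatter). Compound 4 `Cc1cc(/C=N/NC(=O)Nc2ccc(Oc3ccnc(-c4nncn4CCN(C)C)c3)c(F)c2)cc(C)c1O` differs from compound 2 by 4-hydroxy-3,5-dimethylphenyl in place of 2,4-difluorophenyl on a carbon with a double bond to nitrogen. Within the data shown here, the steps that bear on this are the exchanges of the aryl group on the same carbon: no change at the digits printed from compound 2 to compound 3 (within the scatter) and a 1.0-fold lower number from compound 1 to compound 3 (0.01 log units; within the scatter), both flat. The same kind of exchange has therefore left the number unmoved twice, and the step of a 1.0-fold higher number from compound 2 to compound 4 (0.00 log units; within the scatter) is expected to be none beyond the scatter. Compound 4 is estimated at 1950 nM, range 1000 nM to 3900 nM.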

Compound 4, half-maximal inhibitory concentration: 2010 nM
Compound 4: the middle estimate sits 1.0-fold (0.01 log units) below what was measured, and the stated range covers the measured number.
By their numbers in this assay, from the lowest: compounds 2, 3, 1 and 4 (each within the scatter of the next).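

In this assay the 4-hydroxy-3,5-dimethylphenyl group gives a 1.0-fold higher number from compound 2 to compound 4 (0.02 log units; within the scatter), a 1.0-fold higher number from compound 3 to compound 4 (0.02 log units; within the scatter) and a 1.0-fold higher number from compound 1 to compound 4 (0.01 log units; within the scatter), so all three steps lie within the scatter. On this carbon with a double bond to nitrogen, an aryl group carrying methyl groups and a hydroxyl thus reads level with the fluorinated and dihydroxylated aryl groups. No supporting data bear on this flatness.

Every compound shown keeps a six-membered aromatic ring of carbon here. As far as these compounds go, whether a cyclohexyl group, or a phenyl group bearing a carboxylic acid or an amine, would also read level remains open.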